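Replacing an Amino Hydrogen with 2-Ethoxyethyl: Cytotoxicity Expectation

The source may report more compounds than this note shows. Statements on the series, on what has been measured and on what is new or still open speak of the compounds shown alone.

Measured compounds:
compound 1, `CNc1ccc2sc(-c3c(Cl)nc(N)nc3N[C@@H]3C[C@H](CO)[C@@H](O)[C@H]3O)nc2c1`, 20000 nM
compound 2, `Cc1nc(N)nc(N[C@@H]2C[C@H](CO)[C@@H](O)[C@H]2O)c1-c1nc2ccccc2s1`, 4000 nM

Among the compounds with values here, the two measured compounds share a core carrying the same cyclopentane-derived amine and differ in several places at once, so no single step between them is defined; only their two values can be compared. In an ADME assay on cells (Homo sapiens) for cytotoxicity, read by polymerase chain reaction, with a stated time of 3 days (on this read-out higher numbers stand for lower toxicity in this test and lower numbers for higher toxicity in this test), compound 1 gives 20000 nM, while compound 2 gives 4000 nM, the lower of the two numbers, and the gap between them is beyond the usual scatter. On these numbers compound 2 therefore stands as the more toxic of the pair.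

Compound 3, `CCOCCNc1nc(C)c(-c2nc3ccccc3s2)c(N[C@@H]2C[C@H](CO)[C@@H](O)[C@H]2O)n1`, is not yet measured. It differs from compound 2 in one place: 2-ethoxyethyl in place of hydrogen on a nitrogen on an aromatic ring. The change adds 2-ethoxyethyl to the amino nitrogen on the aromatic ring and leaves the rest of the structure intact. Nothing measured here shows how such a change shifts this read-out. The expected step from compound 2 to compound 3 in this assay is a 1.3-fold higher number from compound 2 to compound 3 (0.10 log units; within the scatter), small and not clearly beyond the scatter in either direction. Compound 3 is accordingly estimated at 5000 nM, within a range from 1500 nM to 16000 nM.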

Compound 3, half-maximal cytotoxic concentration: 18000 nM
For compound 3 the middle estimate is 3.6-fold (0.56 log units) below the measured one; the measured number lies above the stated range.
By their numbers in this assay, from the lowest: compound 2; then compounds 3 and 1 (each within the scatter of the next).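

In this assay the amino nitrogen on the aromatic ring proves to be a place where a single change moves the read-out: 2-ethoxyethyl in place of hydrogen gives a 4.5-fold higher number from compound 2 to compound 3 (0.65 log units; beyond the scatter) and so points towards lower toxicity in this test, a modest step but one beyond the scatter. The two earlier compounds differ in several places at once, so they could not tie any shift to this nitrogen, whereas this pair differs in that one place alone. No supporting data accompany the result to explain the rise, and it stands as an observation on this one pair.

The compounds shown leave open whether the step belongs to 2-ethoxyethyl in particular or would come with any chain on this nitrogen, such as a plain ethyl group or a longer alkyl chain. They also leave open whether an amine or a carboxylic acid at the end of the chain would move the number the same way, and whether the same change on the core of compound 1 would give a step of similar size.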